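A Cyclohexylmethyl Amide in Place of Butyl

The source may hold more compounds than are shown below. What is called first, only, known or untested is meant among the compounds shown, and "the series" means these compounds.

Compound 1 `CCC(NC(=O)C(CC(C)C)NC(=O)OCc1ccccc1)C(=O)C(=O)OC`: 280000 nM
Compound 2 `CCOC(=O)C(=O)[C@H](CC)NC(=O)[C@H](CC(C)C)NC(=O)[C@H](CC(C)C)NC(=O)c1ccc2ccccc2c1`: 78000 nM
Compound 3 `CCCCNC(=O)C(=O)C(CC)NC(=O)C(CC(C)C)NC(=O)OCc1ccccc1`: 35000 nM

All three values come from a functional assay for inhibition, with Rattus norvegicus as the target, at pH 7.35; a higher number here means a weaker inhibitor, a lower number a stronger inhibitor. Of the three compounds, compound 3 has the lowest number and is the strongest inhibitor, with its value lying below those of compound 2 and compound 1. The next compound, compound 4 `CCC(NC(=O)C(CC(C)C)NC(=O)OCc1ccccc1)C(=O)C(=O)NCC1CCCCC1`, keeps the core of compound 3 and carries a change at the end of its amide: cyclohexyl in place of propyl on a saturated chain carbon bound to an amide-type nitrogen. In words, cyclohexyl stands in place of propyl on a saturated chain carbon bound to an amide-type nitrogen, so that butylcarbamoyl becomes (cyclohexylmethyl)carbamoyl.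

Among the measured compounds shown here, only one measured step touches this part of the molecule: an 8.0-fold lower number from compound 1 to compound 3 (0.90 log units; beyond the scatter), where butylamino replaced methoxy on a carbonyl carbon. That step shows that this carbonyl substituent can shift the number in this assay. However, it exchanged methoxy for an amine-derived group, whereas compound 4 retains the amide and alters only its alkyl portion. A smaller step is therefore expected, possibly slightly downward and perhaps not beyond the scatter. The expected change is a 1.4-fold lower number from compound 3 to compound 4 (0.15 log units; within the scatter). Compound 4 is estimated at 25000 nM, with an expected range from 9000 nM to 70000 nM.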

Compound 4, half-maximal inhibitory concentration: 66000 nM
Compound 4: middle estimate off by 2.6-fold (0.42 log units), on the low side, and the stated range covers the measured number.
By their numbers in this assay, from the lowest: compounds 3, 4 and 2 (each within the scatter of the next, the first and the last beyond it); then compound 1.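

Exchanging propyl for cyclohexyl on a saturated chain carbon bound to an amide-type nitrogen gives a 1.9-fold higher number from compound 3 to compound 4 (0.28 log units; within the scatter) in this assay, so butylcarbamoyl and (cyclohexylmethyl)carbamoyl cannot be told apart at this position, even though the change brings in a six-membered non-aromatic ring. Set against the methoxy compound, the cyclohexylmethyl amide gives a 4.2-fold lower number from compound 1 to compound 4 (0.63 log units; beyond the scatter), so a second amide now shares the beyond-scatter separation from the methoxy compound that butylamino first showed. No measured evidence accounts for these results.

The compounds shown leave open whether an aromatic group such as benzyl, or a much shorter chain such as methyl, on this amide nitrogen would separate from butyl. They also leave open how a carboxylic acid or a primary amide at this carbonyl carbon would read.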